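The compounds below may be only part of what the source reports. "The series", "measured", "known", "first", "only" and "open" are said of these compounds alone.

Measured compounds and their values in an assay on isolated protein for inhibition of protein kinase C zeta type (Homo sapiens), read by mobility shift assay, tested at 30 uM; on this read-out lower numbers stand for less inhibition and higher numbers for more inhibition at the one concentration tested (going by the name of the read-out):

Compound 1 `CC(=O)Nc1nn(C)c2cc(-c3ccccc3)[nH]c(=O)c12`: 28%
Compound 2 `Cc1cc2c(c(N)nn2C)c(N2CCCCC2)n1`: -152%
Compound 3 `Nc1c2c(=O)[nH]c(-c3ccccc3)cc2nn1-c1ccccc1`: -163%

Among these three numbers compound 3 stands lowest. Compound 2 comes nearest to it, with a number higher by a margin that is beyond the scatter, and compound 1 lies furthest off, far higher and well beyond the scatter. Negative numbers on this read-out mean the signal moved the opposite way from inhibition, so compound 3 and compound 2 both show no inhibition at all at the concentration tested, while compound 1 shows a modest amount.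

The next compound, compound 4 `COc1ccc(-c2cc3nn(-c4ccccc4)c(N)c3c(=O)[nH]2)cc1`, has not yet been measured. It differs from compound 3 in one place:

methoxy in place of hydrogen on an aromatic carbon

Within the data shown here, no pair of measured compounds differs in just one place, so there is no measured step of this kind to lean on. With only the change itself to go by, the expected step is a number 23 percentage points higher from compound 3 to compound 4 (beyond the scatter), small and upward, and most likely within the scatter. For compound 4 in this assay the estimate is -140%, with a range from -220% to -40%.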

Compound 4, a percentage reported as inhibition, at one concentration (the size of the read-out at that concentration, not a potency): 0%
For compound 4 the middle estimate is 140 percentage points below the measured one; the whole stated range lies below it.
By their numbers in this assay, from the lowest: compound 3; then compound 2; then compound 4; then compound 1.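

In this assay, the change from phenyl to 4-methoxyphenyl, with the methoxy para to a large group, gives a large move, a number 163 percentage points higher from compound 3 to compound 4 (beyond the scatter), so this position is not silent and adding only two heavy atoms here can shift the read-out strongly. Compound 4 reads 0%, which means that the change takes away a strongly negative number but does not yet produce any measurable inhibition. Nothing available here explains why the number moves.

A single step cannot show whether the shift is specific to methoxy or would also appear with a hydroxyl, a chlorine or an ethoxy in the same place. It also leaves open whether the same methoxy would have a similar effect on the other phenyl ring of compound 3 .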